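Working notes: cytotoxicity series, next compound to be measured

The compounds below may be only part of what the source reports. "The series", "measured", "known", "first", "only" and "open" are said of these compounds alone.

Measured so far in a functional assay on A549 cells (Homo sapiens) for cytotoxicity, read by sulforhodamine B assay, with a stated time of 48 h; a higher number here means a weaker inhibitor, a lower number a stronger inhibitor: compound 1 `CC(=O)OC[C@H]1O[C@@H](n2cc(Cn3cc(/C=C4/C(=O)Nc5ccc(F)cc54)c4ccccc43)nn2)[C@H](OC(C)=O)[C@@H](OC(C)=O)[C@@H]1OC(C)=O` gives 36900 nM; compound 2 `CC(=O)OC[C@H]1O[C@@H](n2cc(CN3C(=O)/C(=C\C=C\c4ccccc4)c4ccccc43)nn2)[C@H](OC(C)=O)[C@@H](OC(C)=O)[C@@H]1OC(C)=O` gives 58400 nM. Compound 3 `CC(=O)OC[C@H]1O[C@@H](n2cc(CN3C(=O)/C(=C/C=C/c4ccccc4)c4ccccc43)nn2)[C@H](OC(C)=O)[C@@H](OC(C)=O)[C@@H]1OC(C)=O` gives only a limit in this assay, > 100000 nM.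

Compound 3 thus stands at the limit, with no number of its own. For the measured compounds named here, the one measured step that reaches it, an at least 1.7-fold higher number from compound 2 to compound 3 (0.23 log units; that floor lies within the scatter), ends at that limit (the limit of > 100000 nM in this assay, at which 1 of the 3 values shown sits) and rests on a change in drawn configuration alone (the fact that compounds 2 and 3 differ only in the configuration as drawn).

Compound 4 `CC(=O)OC[C@H]1O[C@@H](n2cc(CN3C(=O)/C(=C/c4ccc5ccccc5c4)c4ccccc43)nn2)[C@H](OC(C)=O)[C@@H](OC(C)=O)[C@@H]1OC(C)=O` differs from compound 3 by naphthalen-2-yl in place of 2-phenylethenyl on a double-bonded chain carbon bound to a double-bonded ring carbon. Going by the values given here, no measured step covers such an exchange, so the measured steps give no size or direction for it beyond the scatter. Compound 4 is therefore expected close to compound 3, estimated at 90000 nM, ranging from 30000 nM to 300000 nM. The expected step is an at least 1.1-fold lower number from compound 3 to compound 4 (0.04 log units; that floor lies within the scatter).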

Compound 4, half-maximal inhibitory concentration: 30900 nM
Compound 4: middle estimate off by 2.9-fold (0.46 log units), on the high side; the range from low to high includes it.
By their numbers in this assay, from the lowest: compounds 4, 1 and 2 (each within the scatter of the next). At a limit, above all of these: compound 3.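

At this place, naphthalen-2-yl in place of 2-phenylethenyl gives, in this assay, an at least 3.2-fold lower number from compound 3 to compound 4 (0.51 log units; beyond the scatter), the only step shown that lies beyond the scatter. This step shows that the change can bring a measurable value at this place, where compound 3 has only a limit. Its size is a floor and not a measured difference, since one end is not a number: the limit of > 100000 nM in this assay, at which 1 of the 4 values shown sits.

Open, as far as these compounds go, is how a plain phenyl, a pyridine ring or a carboxylic acid on this carbon would read. Also open, from the compounds shown here alone, is whether the naphthalen-2-yl compound with its double bond drawn the other way would match compound 4.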